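A few compounds are considered here, and "the series" means these few. Any claim that something is new, unique, unknown or untested is made for them only; others in the source may bear on it.

In an ADME assay on BHK cells (Mesocricetus auratus) for cytotoxicity, read by MTT assay, with a stated time of 96 h (a lower number here means that less compound is tolerated, a higher number that more compound is tolerated), compound 3 `Nc1ccc(-c2nc3cc(Cl)c(Cl)cc3[nH]2)cc1` gives 30000 nM. Compound 1 `COc1ccc(-c2nc3cc(C(F)(F)F)ccc3[nH]2)c(OC)c1OC` gives 32000 nM, which lies within the scatter of the value for compound 3, so these two numbers sit level. Compound 2 `O=[N+]([O-])c1ccc(-c2nc3cc(Cl)c(Cl)cc3[nH]2)cc1` is reported only as a limit, > 100000 nM.

Compound 4 `CC(=O)Nc1ccc(-c2nc3cc(Cl)c(Cl)cc3[nH]2)cc1` differs from compound 3 by acetyl in place of hydrogen on a nitrogen on an aromatic ring, with acetyl in place of hydrogen on a nitrogen on an aromatic ring, that is, amino to acetamido. Within the data shown here, no measured step covers this change directly. The nearest evidence is an at least 3.3-fold lower number from compound 2 to compound 3 (0.52 log units; beyond the scatter), with amino in place of nitro on an aromatic carbon. Its size is only a bound, as one end of it is a limit. It does show that the form carrying the free amino group has the lower number of that pair, though the change there is a different one.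

A small step to a higher number in this assay is therefore expected, possibly none beyond the scatter. The expected step is a 1.5-fold higher number from compound 3 to compound 4 (0.18 log units; within the scatter). For compound 4 the estimated value is 45000 nM, with an expected range of 15000 nM to 100000 nM.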

Compound 4, half-maximal cytotoxic concentration: > 100000 nM
Compound 4: no number, only a limit; the forecaster's own chance of this, stated with the estimate: 25%; middle value at least 2.2-fold (0.34 log units) away from the limit.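

In this assay, acetyl in place of hydrogen on the nitrogen gives an at least 3.3-fold higher number from compound 3 to compound 4 (0.52 log units; beyond the scatter). Read with an at least 3.3-fold lower number from compound 2 to compound 3 (0.52 log units; beyond the scatter), this leaves compound 3, with its free amino group, holding the lower number against both the nitro form and the acetamido form, so the lower tolerance does not survive acylation of that nitrogen; both step sizes are bounds only. Compound 4 is reported only as a limit, as is compound 2, so the step between them cannot be read: the limit of > 100000 nM in this assay, at which 2 of the 4 values shown sit.

Any order between nitro and acetamido therefore stays unknown. Also open, going by these compounds, is whether the lower number belongs to the amino group as such: a dimethylamino group, a longer acyl chain or a carboxylic acid in the same place would test that.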